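Replacing one amide substituent of compound 1

A few compounds are considered here, and "the series" means these few. Any claim that something is new, unique, unknown or untested is made for them only; others in the source may bear on it.

Compound 1 `CNC(=O)[C@@H](NC(=O)[C@](O)(CCN(Cc1ccc(Br)cc1)NC(=O)[C@@H](NC(=O)OC)C(C)(C)C)Cc1ccccc1)C(C)(C)C` gives > 10000 nM
Compound 2 `CNC(=O)[C@@H](NC(=O)[C@@](O)(CCN(Cc1ccc(Br)cc1)NC(=O)[C@@H](NC(=O)OC)C(C)(C)C)Cc1ccccc1)C(C)(C)C` gives > 10000 nM

In an ADME assay on MT4 cells (Homo sapiens) for cytotoxicity, read by XTT assay, with a stated time of 5 days (on this read-out higher numbers stand for lower toxicity in this test and lower numbers for higher toxicity in this test), compound 1 gives > 10000 nM, which is a limit of the assay and not a number. Compound 2 gives > 10000 nM, also a limit. Going by the values given here, the only measured step is a step that the two limits leave unreadable from compound 1 to compound 2; it reflects the fact that compounds 1 and 2 differ only in the configuration as drawn and is bounded by the limit of > 10000 nM in this assay, at which 2 of the 2 values shown sit. Compound 3 `COCCNC(=O)[C@@H](NC(=O)[C@](O)(CCN(Cc1ccc(Br)cc1)NC(=O)[C@@H](NC(=O)OC)C(C)(C)C)Cc1ccccc1)C(C)C` differs from compound 1 by a group of 11 heavy atoms (8 carbon, 1 nitrogen, 2 oxygen; no ring) in place of a group of 9 heavy atoms (7 carbon, 1 nitrogen, 1 oxygen; no ring), on an amide-type nitrogen. Among the compounds with values here, no measured step covers this change. With compound 1 at > 10000 nM, a limit, no step beyond the scatter is expected in this assay. The expected step is a step that the limit leaves unreadable from compound 1 to compound 3. For compound 3 the estimate is 15000 nM, with an expected range from 6000 nM to 40000 nM.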

Compound 3, half-maximal cytotoxic concentration: > 10000 nM
Compound 3 was reported as a limit; the forecaster's own chance of this, stated with the estimate: 85%; the middle value lies beyond the limit too.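

Compound 3 gives > 10000 nM, a limit and not a number, so its step from compound 1, also a limit, cannot be read. The compounds shown leave open whether replacing this amide substituent changes cytotoxicity at all.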